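Series notes: pyridin-3-yl in place of 4-fluorophenyl

This account rests on a few compounds, and the source may have more. Where it says the series, first, only, none or still open, it means among the compounds named here.

Measured in an assay on HEK293 cells for inhibition of SCN8A/SCN1B (Homo sapiens), read by patch clamp, with a stated time of 20 min; a higher number here means a weaker inhibitor, a lower number a stronger inhibitor:
compound 1 `CC[C@H](Nc1ccc(S(=O)(=O)Nc2nccs2)cc1)c1ccccc1` gives 1770 nM
compound 2 `C[C@H](Nc1cc(F)c(S(=O)(=O)Nc2nccs2)cc1Cl)c1ccccc1` gives 20 nM
compound 3 `C[C@H](Nc1cc(F)c(S(=O)(=O)Nc2nccs2)cc1Cl)c1ccc(F)cc1` gives 230 nM

Compound 3 stands second highest of the three numbers in this assay, nearer to compound 1 than to compound 2. Among the measured compounds shown here, the one step that changes a single place separates it from compound 2: a 12-fold higher number from compound 2 to compound 3 (1.06 log units; beyond the scatter).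

Compound 4 `C[C@H](Nc1cc(F)c(S(=O)(=O)Nc2nccs2)cc1Cl)c1cccnc1` differs from compound 3 by pyridin-3-yl in place of 4-fluorophenyl on a saturated chain carbon bound to a nitrogen on an aromatic ring and a saturated chain carbon. For the measured compounds named here, no measured step touches a pyridin-3-yl; the recorded step a 12-fold higher number from compound 2 to compound 3 (1.06 log units; beyond the scatter) concerns only a fluoro on the ring and says nothing about a ring nitrogen. As far as these compounds go, the fluoro leaves here as well, which alone would point downward, but the nitrogen is untested. The expected step of a 1.3-fold higher number from compound 3 to compound 4 (0.12 log units; within the scatter) is therefore not beyond the scatter, with a wide range around it. Compound 4 is estimated at 300 nM, between 60 nM and 1500 nM.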

Compound 4, half-maximal inhibitory concentration in the SCN8A/SCN1B assay: 80 nM
Estimate against measurement, compound 4: 3.8-fold (0.57 log units) above, and the stated range covers the measured number.
By their numbers in the SCN8A/SCN1B assay, from the lowest: compound 2; then compound 4; then compound 3; then compound 1.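

In the SCN8A/SCN1B assay, this saturated chain carbon accepts a ring nitrogen: pyridin-3-yl in place of 4-fluorophenyl gives a 2.9-fold lower number from compound 3 to compound 4 (0.46 log units; beyond the scatter), so the fluoro-bearing ring is the poorer of the two here. The ring nitrogen still does not match plain phenyl in the SCN8A/SCN1B assay, with a 4.0-fold higher number from compound 2 to compound 4 (0.60 log units; beyond the scatter). In a physicochemical assay for lipophilicity, read by LC-MS, in phosphate buffer, measured as octanol-water partition, with a stated time of 1 h, at pH 7.4 (a higher number here means a more lipophilic compound, a lower number a more polar compound), compound 3 gives 3.1 and compound 4 gives 1.7. The same change also makes the compound far more polar in the physicochemical assay: the measured distribution coefficient of compound 3, 3.1, and of compound 4, 1.7, a number 1.40 log units lower (beyond the scatter)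

Open, as far as these compounds go, is whether an amine or a carboxylic acid on this ring would keep inhibition in the SCN8A/SCN1B assay while holding the lower lipophilicity seen in the physicochemical assay. One pair also cannot show how inhibition tracks lipophilicity across the series.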